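Removing a Methoxy Group: Compound 1 to Compound 4

The compounds below may be only part of what the source reports. "The series", "measured", "known", "first", "only" and "open" are said of these compounds alone.

Of the compounds shown here, three sharing one core have been tested in a functional assay on BXPC-3 cells (Homo sapiens) for cytotoxicity, read by MTT assay, with a stated time of 72 h; a lower number here means a stronger inhibitor, a higher number a weaker inhibitor. The bare core, compound 2 `O=C1C=CC(=O)c2ncncc21`, gives 19400 nM. Adding a substituted aniline to that core lowers the number: compound 3 `COc1cccc(NC2=CC(=O)c3ncncc3C2=O)c1` gives 1800 nM, and compound 1 `COc1ccc(-c2ccc(NC3=CC(=O)c4ncncc4C3=O)cc2)cc1` gives 3500 nM. Among these three numbers compound 1 holds the second highest place. Its number is clearly lower than that of compound 2, a gap that lies beyond the usual scatter, while the gap to compound 3 is within the scatter, so the two cannot be ranked against each other.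

Compound 4 `O=C1C(Nc2ccc(-c3ccccc3)cc2)=CC(=O)c2ncncc21` differs from compound 1 in one place only: hydrogen in place of methoxy on an aromatic carbon. The methoxy sits on the outer ring of the biphenyl, far from the core.

Going by the values given here, no measured pair in this set isolates such a change, so there is no direct precedent. A small group on a distant ring often matters little, and in this case the expected step from compound 1 to compound 4 is a 1.1-fold higher number from compound 1 to compound 4 (0.06 log units; within the scatter), which would stay within the scatter. Compound 4 is therefore expected to give about 4000 nM, with a plausible range from 1500 nM to 11000 nM.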

Compound 4, half-maximal inhibitory concentration: 500 nM
Compound 4: the middle estimate sits 8.0-fold (0.90 log units) above what was measured, outside the stated range (below it).
By their numbers in this assay, from the lowest: compound 4; then compounds 3 and 1 (each within the scatter of the next); then compound 2.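

In this assay, the change from 4-methoxyphenyl to phenyl gives a 7.0-fold lower number from compound 1 to compound 4 (0.85 log units; beyond the scatter), so this position is not a silent spot on the molecule. The earlier compounds shown here could show only that adding a substituted aniline to the shared core goes with a lower number, since none of them formed a pair differing in one place. Going by these compounds alone, this pair is the first to show that a single small group, here a methoxy on an aromatic carbon, can by itself move the number beyond the scatter, and no data at hand say why the number falls.

Within the data shown here, with only one change at this position, it remains unknown whether the lower number is specific to hydrogen or whether a fluorine, a hydroxyl or an amine in place of the methoxy would give a similar result. As far as these compounds go, it is also open whether moving the methoxy to another carbon of the same ring would matter, and whether removing the methoxy from compound 3 would produce a comparable step.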